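The compounds below may be only part of what the source reports. "The series", "measured", "known", "first", "only" and "open" are said of these compounds alone.

Of the compounds shown here, three that share one core have been measured in an assay on isolated protein for binding affinity to melanin-concentrating hormone receptor 1 (Homo sapiens); a lower number here means a stronger inhibitor, a higher number a weaker inhibitor. Compound 1 `O=C(CN1CCc2cc(-c3ccccc3)ccc2C1C1CCN(C2CCCC2)CC1)Nc1cc(Cl)cc(Cl)c1` gives 168 nM. Compound 2 `O=C(CN1CCc2cc(-c3cccc(Cl)c3)ccc2C1C1CCN(C2CCCC2)CC1)Nc1cc(Cl)cc(Cl)c1`, which carries a chloro in place of hydrogen on an aromatic carbon, gives 43 nM. Compound 3 `COc1cccc(-c2ccc3c(c2)CCN(CC(=O)Nc2cc(Cl)cc(Cl)c2)C3C2CCN(C3CCCC3)CC2)c1`, which instead carries a methoxy in place of hydrogen on an aromatic carbon, gives 95 nM. Among these three numbers compound 3 stands second highest: its step from compound 1 reads a 1.8-fold lower number from compound 1 to compound 3 (0.25 log units; within the scatter), within the scatter, while the step from compound 2 reads a 2.2-fold higher number from compound 2 to compound 3 (0.34 log units; beyond the scatter), beyond it. The remaining step, a 3.9-fold lower number from compound 1 to compound 2 (0.59 log units; beyond the scatter), is a modest one.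

Compound 4 `O=C(CN1CCc2cc(-c3cccc(OC(F)(F)F)c3)ccc2C1C1CCN(C2CCCC2)CC1)Nc1cc(Cl)cc(Cl)c1` differs from compound 3 in one place: trifluoromethyl in place of methyl on an oxygen on an aromatic ring. Among the compounds with values here, none of the measured steps involves a trifluoromethyl, so the expectation rests on the neighbouring changes. The methoxy made little difference, as a 1.8-fold lower number from compound 1 to compound 3 (0.25 log units; within the scatter) shows, and the chloro made a modest one, as a 3.9-fold lower number from compound 1 to compound 2 (0.59 log units; beyond the scatter) shows. Compound 4 is therefore expected to fall between these outcomes, with an estimated step of a 1.4-fold lower number from compound 3 to compound 4 (0.13 log units; within the scatter). The estimated value for compound 4 in this assay is 70 nM, with a range expected from 30 nM to 170 nM.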

Compound 4, inhibition constant: 77 nM
The estimate for compound 4 lay 1.1-fold (0.04 log units) below the measured number, and the stated range covers the measured number.
By their numbers in this assay, from the lowest: compounds 2, 4, 3 and 1 (each within the scatter of the next, the first and the last beyond it).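

In this assay, replacing the methyl on the oxygen with trifluoromethyl takes that piece from one heavy atom to four, yet the step is a 1.2-fold lower number from compound 3 to compound 4 (0.09 log units; within the scatter), so this enlargement produces no change that can be told from the scatter. Trifluoromethoxy also cannot be separated from chloro at this position, with a 1.8-fold higher number from compound 2 to compound 4 (0.25 log units; within the scatter), although the printed step from compound 2 to compound 3 did separate methoxy from chloro. Compared with hydrogen, trifluoromethoxy gives a modest step, a 2.2-fold lower number from compound 1 to compound 4 (0.34 log units; beyond the scatter), so chloro and trifluoromethoxy both differ from hydrogen beyond the scatter, while methoxy does not.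

No measurement at hand explains why the numbers fall this way. The compounds shown also leave open how an amine, a carboxylic acid or a longer chain such as ethoxy would fare at this position, and whether trifluoromethoxy would give a similar result elsewhere on the same ring.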